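The source may report more compounds than this note shows. Statements on the series, on what has been measured and on what is new or still open speak of the compounds shown alone.

Measured compounds and their values in a functional assay on HeLa cells (Homo sapiens) for antiproliferative activity, read by MTT assay, with a stated time of 48 h; on this read-out higher numbers stand for weaker inhibition and lower numbers for stronger inhibition:

Compound 1, `Cc1cnc(Nc2ccc(S(C)(=O)=O)cc2)nc1Nc1nc2ccccc2s1`, gives 460 nM.
Compound 3, `Cc1cnc(Nc2ccc(S(N)(=O)=O)cc2)nc1Nc1nc2ccccc2s1`, gives 2800 nM.
Compound 2, `NS(=O)(=O)c1ccc(Nc2ncc(F)c(Nc3nc4ccc(Cl)cc4s3)n2)cc1`, gives 8770 nM.

Compound 1 and compound 3 share one core and differ in a single place. The change is methyl in place of amino on a sulfonyl sulfur. Measured in this assay, this change gave a 6.1-fold lower number from compound 3 to compound 1 (0.78 log units; beyond the scatter).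

Compound 2 is built on a different core. How the core of compound 2 differs from the core of compound 3 is not broken down here. Of the three measured compounds, compound 2 has the highest number, and its steps to compound 3 and to compound 1 both lie beyond the usual scatter.

Compound 4, `CS(=O)(=O)c1ccc(Nc2ncc(F)c(Nc3nc4ccc(Cl)cc4s3)n2)cc1`, has not yet been measured in this assay. It differs from compound 2 in one place only: methyl in place of amino on a sulfonyl sulfur. Among the compounds with values here, this is the same change as the one from compound 3 to compound 1, and it sits at a place described in the same words, a sulfonyl sulfur whose other neighbour is an aromatic carbon. The expectation is therefore that the change from compound 2 to compound 4 will move the number in the same direction and by roughly the same amount, since the change from compound 3 to compound 1 gave a 6.1-fold lower number from compound 3 to compound 1 (0.78 log units; beyond the scatter). The expected step is a 5.8-fold lower number from compound 2 to compound 4 (0.77 log units; beyond the scatter). The surrounding core is different, so a wider range is allowed around this expectation.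

For compound 4 in this assay, the estimated value is 1500 nM, expected to fall between 500 nM and 4500 nM.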

Compound 4, half-maximal inhibitory concentration: > 50000 nM
Compound 4 gave a limit, no number (the forecaster's own chance of this, stated with the estimate: 5%); middle value at least 33-fold (1.52 log units) from the limit.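

In this assay, compound 4 gives > 50000 nM, which is a limit of the assay and not a number. Even so, methyl in place of amino on a sulfonyl sulfur gave an at least 5.7-fold higher number from compound 2 to compound 4 (0.75 log units; beyond the scatter), so the change moved the number in opposite directions on the two cores, and the gap between the two steps is larger than chance scatter would explain: the same change on two cores in this assay, a 6.1-fold lower number (0.78 log units; beyond the scatter) from compound 3 to compound 1 and an at least 5.7-fold higher number (0.75 log units; beyond the scatter) from compound 2 to compound 4, at least 34-fold (1.54 log units) apart, beyond the scatter of two such steps This shows that, in this series, the step seen on one core did not predict even the direction of the step on the other, but with only one pair on each core it does not show which feature of the cores is responsible, nor what would happen on a further core.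

The compounds shown leave open where the true value of compound 4 lies, and so how large its step from compound 2 really is. They also leave open whether an ethyl or a dimethylamino group on the sulfonyl sulfur would behave like the methyl or like the amino on each of the two cores.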